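The compounds below may be only part of what the source reports. "The series", "measured", "known", "first", "only" and "open" are said of these compounds alone.

Measured in a functional assay on A549 cells (Homo sapiens) for antiproliferative activity, read by MTT assay, with a stated time of 48 h; a lower number here means a stronger inhibitor, a higher number a weaker inhibitor:
- Compound 1 `COc1ccc2[nH]c(-c3cn(-c4ccccc4)nc3-c3ccccc3)nc2c1`: 1230 nM
- Compound 2 `Fc1ccc(-c2nn(-c3ccccc3)cc2-c2nc3cc(F)ccc3[nH]2)cc1`: 1130 nM
- Compound 3 `Fc1ccc(-c2nn(-c3ccccc3)cc2-c2nc3cc(Br)ccc3[nH]2)cc1`: 5830 nM

Compound 3, at 5830 nM, has the highest number of the three, so it is the weakest inhibitor in this small set. Compound 4 `COc1ccc2[nH]c(-c3cn(-c4ccccc4)nc3-c3ccc(F)cc3)nc2c1` is built from compound 3 by one change, methoxy in place of bromo on an aromatic carbon.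

For the measured compounds named here, only one measured step touches this place on the molecule. Swapping the halogen gave a 5.2-fold higher number from compound 2 to compound 3 (0.71 log units; beyond the scatter), a modest change, and it shows that the bromo compound is the weaker of that pair. Going by the values given here, no measured step goes directly from bromo to methoxy. However, compound 1 already carries the methoxy and gives 1230 nM, although it differs from compound 4 elsewhere. A clear move towards a lower number is therefore expected, similar in size to the halogen step. The expected change is a 4.5-fold lower number from compound 3 to compound 4 (0.65 log units; beyond the scatter). For compound 4 the estimated value is 1300 nM, with a likely range from 550 nM to 3200 nM.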

Compound 4, half-maximal inhibitory concentration: 1960 nM
Compound 4: the middle estimate sits 1.5-fold (0.18 log units) below what was measured, within the range that was stated.
By their numbers in this assay, from the lowest: compounds 2, 1 and 4 (each within the scatter of the next); then compound 3.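

In this assay, methoxy in place of bromo gives a 3.0-fold lower number from compound 3 to compound 4 (0.47 log units; beyond the scatter) and this step lies beyond the scatter. Methoxy in place of fluoro at the same place gives a 1.7-fold higher number from compound 2 to compound 4 (0.24 log units; within the scatter) and this step lies within the scatter, so fluoro and methoxy cannot be told apart here, and among these three groups only bromo stands out. A second place can now be read too: fluoro in place of hydrogen on an aromatic carbon elsewhere in the molecule gives a 1.6-fold higher number from compound 1 to compound 4 (0.20 log units; within the scatter) and this step also lies within the scatter.

Nothing measured here gives a reason for the bromo result. On these data alone, it remains open whether an amine or a carboxylic acid at this place would behave like fluoro and methoxy or like bromo.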